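Benzyl on the Ring Nitrogen: From Compound 2 to Compound 3

A few compounds are considered here, and "the series" means these few. Any claim that something is new, unique, unknown or untested is made for them only; others in the source may bear on it.

Measured so far:
- compound 1, `COc1ccc2[nH]c(C)c(CCCC(=O)N3CCOCC3)c2c1`, gives 72.9% in an assay on cells for inhibition of Polyunsaturated fatty acid 5-lipoxygenase (Rattus norvegicus), tested at 5 uM; a lower number here means less inhibition, a higher number more inhibition at the concentration tested (going by the name of the read-out)
- compound 2, `COc1ccc2[nH]c(C)c(CCCC(=O)N3CCN(C(=O)OC(C)(C)C)CC3)c2c1`, gives 71.2% in this assay

Compound 2 has the lower of the two numbers, but compound 1 sits within the usual scatter of it, so the two cannot be told apart on these data. Both share the same core, and the two measured compounds differ at the amide end, not at the ring nitrogen.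

Compound 3, `COc1ccc2c(c1)c(CCCC(=O)N1CCN(C(=O)OC(C)(C)C)CC1)c(C)n2Cc1ccccc1`, differs from compound 2 in one place: benzyl in place of hydrogen on an aromatic nitrogen. Going by the values given here, no pair of measured compounds shows what this change does, so there is no measured step to lean on, only the two values of compounds 1 and 2.

With nothing pointing in either direction, the expected step is a number 1.2 percentage points lower from compound 2 to compound 3 (within the scatter), which is no larger than the scatter. The estimate for compound 3 in this assay is 70%, with a range from 50% to 88%.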

Compound 3, a percentage reported as inhibition, at one concentration (the size of the read-out at that concentration, not a potency): 51.5%
The estimate for compound 3 lay 18.5 percentage points above the measured number; the range from low to high includes it.
By their numbers in this assay, from the lowest: compound 3; then compounds 2 and 1 (each within the scatter of the next).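

In this assay, placing benzyl on the aromatic nitrogen in place of hydrogen brings a number 19.7 percentage points lower from compound 2 to compound 3 (beyond the scatter), so this position responds to a change in a way that the two earlier compounds, which differ only at the amide end, could not show. Compound 3 still gives 51.5%, so inhibition at the concentration tested is reduced but not gone. Nothing available here explains why this substitution lowers the number.

Still open, from the compounds shown here alone, is whether the loss belongs to benzyl itself or to any group on this nitrogen, which a methyl group or a longer chain ending in a carboxylic acid could help to separate. Going by these compounds, it is also open whether benzyl would give a similar step with the amide end of compound 1.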